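Phenyl in place of 1-phenylethyl in a weak-binding series

A few compounds are considered here, and "the series" means these few. Any claim that something is new, unique, unknown or untested is made for them only; others in the source may bear on it.

Compound 1 `CCCn1c(=O)[nH]c2nc(-c3ccc(S(=O)(=O)N4CCN(c5cccc(F)c5)CC4)cc3)[nH]c2c1=O`: in an assay on CHO cells for displacement of a labelled ligand from adenosine receptor A3 (Homo sapiens), read by scintillation counting, with a stated time of 45 min, in the presence of a further agent that is not named here (a higher number here means a weaker inhibitor, a lower number a stronger inhibitor), compound 1 gives > 1000 nM, which is a limit of the assay rather than a number.
Compound 2 `CCCn1c(=O)[nH]c2nc(-c3ccc(S(=O)(=O)N4CCN(C(C)c5ccccc5)CC4)cc3)[nH]c2c1=O`: in this assay compound 2 gives > 1000 nM, again a limit and not a number.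

Because both values sit at the limit of > 1000 nM in this assay, at which 2 of the 2 values shown sit, the step that the two limits leave unreadable from compound 1 to compound 2 has no readable size. Going by the values given here, compound 2 therefore stands only at a limit, and the one other value shown is a limit as well. Compound 3 `CCCn1c(=O)[nH]c2nc(-c3ccc(S(=O)(=O)N4CCN(c5ccccc5)CC4)cc3)[nH]c2c1=O` differs from compound 2 by phenyl in place of 1-phenylethyl on an amine nitrogen in a ring. Among the compounds with values here, the only measured step that bears on this change is a step that the two limits leave unreadable from compound 1 to compound 2, which also swaps the group on that ring nitrogen, yet it gives no size and no direction. Nothing in the data points to a shift beyond the scatter, so compound 3 is expected to stay at the limit in this assay. Compound 3 is estimated at 3000 nM, within 800 nM to 15000 nM. The expected step that the limit leaves unreadable from compound 2 to compound 3 is thus essentially none.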

Compound 3, inhibition constant: > 1000 nM
Compound 3: no number, only a limit; the forecaster's own chance of this, stated with the estimate: 80%; the middle value is on the limit's open side.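

No step can be read among compound 1, compound 2 and compound 3, because each gives a limit of the assay rather than a number: the limit of > 1000 nM in this assay, at which 3 of the 3 values shown sit.

On these data alone, how strongly any of the three binds in this assay, and whether the group on the ring nitrogen or the fluoro matters at all, stays open.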